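The source may hold more compounds than are shown below. What is called first, only, known or untested is meant among the compounds shown, and "the series" means these compounds.

Compound 1 `COc1ncnc2c1c(-c1cccs1)cn2[C@@H]1O[C@H](CO)[C@@H](O)[C@H]1O`: 1760 nM in a functional assay on HeLa S3 cells (Homo sapiens) for antiproliferative activity, read by XTT assay, with a stated time of 72 h; a lower number here means a stronger inhibitor, a higher number a weaker inhibitor
Compound 2 `Cc1ncnc2c1c(-c1cccs1)cn2[C@@H]1O[C@H](CO)[C@@H](O)[C@H]1O`: > 15000 nM in this assay, a limit of the assay rather than a number

Compound 1 thus holds the only number shown; compound 2 gives only a limit, and the step of an at least 8.5-fold higher number from compound 1 to compound 2 (0.93 log units; beyond the scatter) records this. Compound 3 `COc1ncnc2c1c(-c1ccco1)cn2[C@@H]1O[C@H](CO)[C@@H](O)[C@H]1O` differs from compound 1 by furan-2-yl in place of thiophen-2-yl on an aromatic carbon. Among the compounds with values here, the one measured step concerns a different place in the shared core and so does not bear on this exchange. With nothing to guide the direction, the expected step of a 1.4-fold higher number from compound 1 to compound 3 (0.15 log units; within the scatter) is one within the scatter. Compound 3 is therefore estimated at 2500 nM, with a range from 800 nM to 8000 nM.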

Compound 3, half-maximal inhibitory concentration: 1020 nM
Compound 3: the middle estimate sits 2.5-fold (0.39 log units) above what was measured; low and high end bracket the measured number.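

In this assay, furan-2-yl in place of thiophen-2-yl gives a 1.7-fold lower number from compound 1 to compound 3 (0.24 log units; within the scatter), so this exchange of one five-membered aromatic ring for another cannot be told apart from repeat measurements. Within the data shown here, this is the first view of this position, since the earlier step concerned a different place on the shared core. Nothing in the data shown bears on why the two rings give such similar results. The compounds shown leave open what a phenyl ring, an amine or a carboxylic acid would do on this aromatic carbon.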